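The compounds below may be only part of what the source reports. "The series", "measured", "known", "first", "only" and "open" are said of these compounds alone.

Working notes on a small series of threonine-derived diamides tested in a functional assay on SiHa cells (Homo sapiens) for cytotoxicity, read by MTT assay, with a stated time of 48 h; a higher number here means a weaker inhibitor, a lower number a stronger inhibitor.

Compound 1 `CCCCCCCCCCCCNC(=O)[C@@H](NC(=O)c1cc2ccccc2n1C)[C@@H](C)O` carries a dodecyl chain on the amide nitrogen and a 1-methyl-1H-indol-2-yl group on the carbonyl carbon. In this assay compound 1 gives only a limit of the assay, > 200000 nM. Compound 2 `CCCCCCCCCCCCNC(=O)[C@@H](NC(=O)/C=C/c1ccccc1)[C@@H](C)O` differs from compound 1 by 2-phenylethenyl in place of 1-methyl-1H-indol-2-yl on a carbonyl carbon. In this assay compound 2 also gives only a limit, > 200000 nM. The step from compound 1 to compound 2 is therefore a step that the two limits leave unreadable from compound 1 to compound 2; both values sit at the limit of > 200000 nM in this assay, at which 2 of the 3 values shown sit.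

Compound 3 `CCCCCCCCCCCCCCCCCCNC(=O)[C@@H](NC(=O)c1cc2ccccc2n1C)[C@@H](C)O` differs from compound 1 by hexyl in place of hydrogen on a saturated chain carbon, ten or more bonds along the chain from an amide-type nitrogen. In this assay, among the measured compounds shown here, compound 3 gives 113000 nM, the only number in the set; the step is an at least 1.7-fold lower number from compound 1 to compound 3 (0.24 log units; that floor lies within the scatter).

Compound 4 `CCCCCCCCCCCCCCCCCCNC(=O)[C@@H](NC(=O)/C=C/c1ccccc1)[C@@H](C)O` is not yet measured. It differs from compound 3 by 2-phenylethenyl in place of 1-methyl-1H-indol-2-yl on a carbonyl carbon, the same change as from compound 1 to compound 2, since the two place lines agree word for word. That earlier step could not be read, so there is no measured size to carry over. With compound 3 at 113000 nM, the expectation for compound 4 is a step of about a 1.4-fold higher number from compound 3 to compound 4 (0.15 log units; within the scatter), that is a value of much the same size. The estimate for compound 4 is 160000 nM, within 60000 nM to 350000 nM.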

Compound 4, half-maximal inhibitory concentration: 35900 nM
Compound 4: the middle estimate sits 4.5-fold (0.65 log units) above what was measured; the measured number lies below the stated range.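

In this assay, 2-phenylethenyl in place of 1-methyl-1H-indol-2-yl on a carbonyl carbon gives a 3.1-fold lower number from compound 3 to compound 4 (0.50 log units; beyond the scatter), a size read on this one core only. The same change from compound 1 to compound 2 cannot be read, so nothing shows whether this size carries over to the core of compound 1, where both values are limits of the assay: the limit of > 200000 nM in this assay, at which 2 of the 4 values shown sit. The other change in the series, hexyl in place of hydrogen on a saturated chain carbon, gives an at least 5.5-fold lower number from compound 2 to compound 4 (0.74 log units; beyond the scatter), and set beside its earlier step it reads: the same change on two cores in this assay, an at least 1.7-fold lower number (0.24 log units; that floor lies within the scatter) from compound 1 to compound 3 and an at least 5.5-fold lower number (0.74 log units; beyond the scatter) from compound 2 to compound 4; the limit leaves it open whether they differ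

The compounds shown leave open whether a chain of intermediate length, such as tetradecyl, already brings the 2-phenylethenyl or the 1-methyl-1H-indol-2-yl series off the limit, and whether a longer chain than that of compound 4 keeps the same direction. Also open, from the compounds shown here alone, is how a plain phenyl group or an amine-bearing aromatic group would compare with 2-phenylethenyl on the same carbonyl carbon.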